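Swapping Chloro for Fluoro on a Dihydrofolate Reductase Inhibitor

A few compounds are considered here, and "the series" means these few. Any claim that something is new, unique, unknown or untested is made for them only; others in the source may bear on it.

Compound 1 `CCN(Cc1nc2cc(C(F)(F)F)ccc2nc1-c1ccccc1)c1ccc(F)cc1`: 3000 nM
Compound 2 `C#CCN(Cc1nc2cc(C(F)(F)F)ccc2nc1-c1ccccc1)c1ccc(Cl)cc1`: 4000 nM

Both were tested in an assay on isolated protein for inhibition of Dihydrofolate reductase (Homo sapiens), read by spectrophotometry; on this read-out higher numbers stand for weaker inhibition and lower numbers for stronger inhibition. In this assay compound 1 gives 3000 nM, while compound 2 gives 4000 nM. Of the two numbers, that of compound 2 is the larger, yet compound 1 sits within the scatter of it, so the two cannot be told apart. Compound 3 `C#CCN(Cc1nc2cc(C(F)(F)F)ccc2nc1-c1ccccc1)c1ccc(F)cc1` is not yet measured; it differs from compound 2 by fluoro in place of chloro on an aromatic carbon. Going by the values given here, no pair of measured compounds isolates this exchange, so there is nothing to set its size. In this assay the exchange is expected to give a 1.1-fold lower number from compound 2 to compound 3 (0.06 log units; within the scatter), a step not beyond the scatter. Compound 3 is estimated at 3500 nM, ranging from 1500 nM to 8000 nM.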

Compound 3, inhibition constant: 8000 nM
Compound 3: middle estimate off by 2.3-fold (0.36 log units), on the low side; the range from low to high includes it.
By their numbers in this assay, from the lowest: compounds 1, 2 and 3 (each within the scatter of the next, the first and the last beyond it).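

In this assay, the exchange of 4-chlorophenyl to 4-fluorophenyl now has a measured size: a 2.0-fold higher number from compound 2 to compound 3 (0.30 log units; within the scatter), so at this ring position the two halogens cannot be told apart. Ethynyl in place of methyl on the chain gives a 2.7-fold higher number from compound 1 to compound 3 (0.43 log units; beyond the scatter), the only single change here that clears the scatter, and it points to weaker inhibition. Nothing available explains either step. From the compounds shown here alone, whether the ethynyl step would hold with chloro on the ring remains open. Also open, going by these compounds, is what an amine in place of the halogen, or a longer chain in place of the ethynyl, would do.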